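Methyl to bromo swap across two cores

This account rests on a few compounds, and the source may have more. Where it says the series, first, only, none or still open, it means among the compounds named here.

Measured so far in a functional assay on A549 cells (Homo sapiens) for inhibition, read by sulforhodamine B assay, with a stated time of 48 h; a lower number here means a stronger inhibitor, a higher number a weaker inhibitor:
compound 1 `CCO[C@H]1C[C@@H](c2coc3ccc(C)cc3c2=O)N(c2ccccc2)O1`: 20700 nM
compound 2 `Cc1ccc2occ([C@@H]3[C@H]4C(=O)N(c5ccccc5)C(=O)[C@H]4ON3c3ccccc3)c(=O)c2c1`: > 60000 nM, a limit of the assay, not a number
compound 3 `O=C1[C@H]2[C@H](ON(c3ccccc3)[C@@H]2c2coc3ccc(Br)cc3c2=O)C(=O)N1c1ccccc1`: 17000 nM

Compound 2 and compound 3 share one core and differ by bromo in place of methyl on an aromatic carbon. The step of an at least 3.5-fold lower number from compound 2 to compound 3 (0.54 log units; beyond the scatter) can only be bounded, because its starting point is the limit (the limit of > 60000 nM in this assay, at which 1 of the 3 values shown sits). Compound 1 has a different core; the difference between the two cores is not broken down here. Compound 1 and compound 3 lie within the scatter of each other in this assay .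

Compound 4 `CCO[C@H]1C[C@@H](c2coc3ccc(Br)cc3c2=O)N(c2ccccc2)O1` is not yet measured. It differs from compound 1 by bromo in place of methyl on an aromatic carbon, the same change as that seen between compound 2 and compound 3, at the same place on the fused ring.

In this assay the expected step is a 2.3-fold lower number from compound 1 to compound 4 (0.36 log units; beyond the scatter), taken smaller than the measured one, because that one rests on the limit of > 60000 nM in this assay, at which 1 of the 3 values shown sits, and the cores are not the same. Compound 4 is estimated at 9000 nM, with a range from 3000 nM to 30000 nM.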

Compound 4, half-maximal inhibitory concentration: 21500 nM
Compound 4: middle estimate off by 2.4-fold (0.38 log units), on the low side; low and high end bracket the measured number.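

In this assay, bromo in place of methyl does not carry over unchanged from one core to the other, and a 1.0-fold higher number from compound 1 to compound 4 (0.02 log units; within the scatter) shows no readable shift on the core of compound 1: the same change on two cores in this assay, an at least 3.5-fold lower number (0.54 log units; beyond the scatter) from compound 2 to compound 3 and a 1.0-fold higher number (0.02 log units; within the scatter) from compound 1 to compound 4, at least 3.6-fold (0.56 log units) apart, beyond the scatter of two such steps. On these data alone, compound 2 gives > 60000 nM, a limit of the assay and not a number, so the step on the other core is only a bound and its true size remains unknown: the limit of > 60000 nM in this assay, at which 1 of the 4 values shown sits. With one pair on each core, this shows that the change cannot be assumed to transfer between these two cores, but it does not show why the pairs differ or how the change would behave on any further core.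

The compounds shown leave open whether another group at this place on the fused ring, such as chloro, methoxy or an amine, would shift the number on either core. They also leave open whether a longer chain in place of the ethoxy group would change the reading for compound 1 or compound 4.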